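The compounds below may be only part of what the source reports. "The series", "measured", "known", "first", "only" and "open" are said of these compounds alone.

Of the compounds shown here, three sharing one core have been measured in a physicochemical assay for lipophilicity, using the shake flask method, measured as octanol-water partition, at pH 7.4; on this read-out higher numbers stand for higher lipophilicity and lower numbers for lower lipophilicity. Compound 1 `COc1cc(/C=C/C(=O)Nc2ccccc2)ccc1OCCCCN1CCCCC1` gives 1.61, compound 2 `COc1cc(/C=C/C(=O)Nc2ccccc2)ccc1OCCCCCN1CCCCC1` gives 1.65, and compound 3 `COc1cc(/C=C/C(=O)Nc2ccccc2)ccc1OCCCCCN1CCCC1` gives 1.64; all three lie within the scatter of one another, so compound 3 stands level with both of its neighbours. Compound 4 `CCN(CC)CCCCCCCCOc1ccc(/C=C/C(=O)Nc2ccccc2)cc1OC` differs from compound 3 by 3-(diethylamino)propyl in place of pyrrolidin-1-yl on a saturated chain carbon, five bonds along the chain from an oxygen on an aromatic ring. The measured steps that bear on this are a number 0.04 log units higher from compound 1 to compound 2 (within the scatter), a number 0.01 log units lower from compound 2 to compound 3 (within the scatter) and a number 0.03 log units higher from compound 1 to compound 3 (within the scatter), each within the scatter, though none of them opens the ring or lengthens the chain as far as this change does. A small rise in this assay is therefore expected, a number 0.31 log units higher from compound 3 to compound 4 (beyond the scatter), with room for no shift at all. Compound 4 is estimated at 1.95, between 1.5 and 2.4.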

Compound 4, partition coefficient: 1.75
The estimate for compound 4 lay 0.20 log units above the measured number; the range from low to high includes it.
By their numbers in this assay, from the lowest: compounds 1, 3, 2 and 4 (each within the scatter of the next).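

In this assay, replacing pyrrolidin-1-yl with the ring-free 3-(diethylamino)propyl leaves the compounds level (a number 0.11 log units higher from compound 3 to compound 4 (within the scatter)), and the same holds against piperidin-1-yl (a number 0.10 log units higher from compound 2 to compound 4 (within the scatter)) and for 4-(diethylamino)butyl in place of piperidin-1-yl (a number 0.14 log units higher from compound 1 to compound 4 (within the scatter)). For the compounds shown here, this position, on a saturated chain carbon, thus takes a much larger change than the earlier steps without leaving the scatter. No evidence at hand accounts for this. Compound 4 changes ring and chain length together, so a diethylamino group on the shorter chain of compound 3 would separate them. From the compounds shown here alone, a morpholin-4-yl group or a carboxylic acid at this position remains open.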